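The source may hold more compounds than are shown below. What is called first, only, known or untested is meant among the compounds shown, and "the series" means these compounds.

In an assay on CHO cells for displacement of a labelled ligand from adenosine receptor A1 (Homo sapiens), read by scintillation counting, with a stated time of 3 h (a lower number here means a stronger inhibitor, a higher number a weaker inhibitor), the three measured compounds stand as follows:

compound 1, `Nc1nc(-c2ccccc2)nc2sc(-c3ccco3)nc12`: 33 nM
compound 2, `Nc1nc(-c2cccc(O)c2)nc2sc(-c3ccco3)nc12`: 51 nM
compound 3, `Nc1nc(-c2ccco2)nc2sc(-c3ccco3)nc12`: 69 nM

For the measured compounds named here, compound 3 carries the highest number of the three, but only one of its two steps goes beyond the scatter: a 2.1-fold higher number from compound 1 to compound 3 (0.32 log units; beyond the scatter), whereas a 1.4-fold higher number from compound 2 to compound 3 (0.13 log units; within the scatter). The remaining step, a 1.5-fold higher number from compound 1 to compound 2 (0.19 log units; within the scatter), is likewise within the scatter. Every one of these steps alters the aryl group on the six-membered ring of the shared core; none of them touches the furan-2-yl on the five-membered ring.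

Compound 4, `Cc1ccc(-c2nc(N)c3nc(-c4ccco4)sc3n2)o1`, differs from compound 3 by methyl in place of hydrogen on an aromatic carbon. This is the change that the measured set does not address: the three measured steps all concern a different position, and the one that adds a small group, a hydroxy on a phenyl, stays within the scatter. Methyl enters here with one carbon and no ring, donors or acceptors, a small change at a place the data leave unexplored.

On that basis the expectation for compound 4 in this assay is a 1.2-fold lower number from compound 3 to compound 4 (0.06 log units; within the scatter), a step of no clear direction and not beyond the scatter. Compound 4 is therefore estimated at 60 nM, within a range from 25 nM to 150 nM.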

Compound 4, inhibition constant: 45.9 nM
Compound 4: the middle estimate sits 1.3-fold (0.12 log units) above what was measured; the measured number falls inside the stated range.
By their numbers in this assay, from the lowest: compounds 1, 4, 2 and 3 (each within the scatter of the next, the first and the last beyond it).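

In this assay, for the compounds shown here, the step (a 1.5-fold lower number from compound 3 to compound 4 (0.18 log units; within the scatter)) gives the first reading of a substituent on the furan-2-yl that the earlier steps only exchanged as a whole, and methyl in place of hydrogen, next to the ring oxygen, does not move the number beyond the scatter. The 5-methylfuran-2-yl group also stands within the scatter of both aryl groups it can be compared with (3-hydroxyphenyl: a 1.1-fold lower number from compound 2 to compound 4 (0.05 log units; within the scatter); phenyl: a 1.4-fold higher number from compound 1 to compound 4 (0.14 log units; within the scatter)), whereas the unsubstituted furan-2-yl stood beyond the scatter of phenyl (a 2.1-fold higher number from compound 1 to compound 3 (0.32 log units; beyond the scatter)), although the methyl step itself is too small to be told from the scatter. No experimental evidence is available here to account for this result.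

The compounds shown leave open whether a longer chain such as propyl, an amine or a carboxylic acid at this same place would keep the number in this range. They also leave open what methyl would do on the other furan-2-yl, which is the same in all four compounds.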